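Alkyne side chain: from compound 3 to compound 4

The compounds below may be only part of what the source reports. "The series", "measured", "known", "first", "only" and "open" are said of these compounds alone.

Measured so far in a functional assay on HepG2 cells (Homo sapiens) for antiproliferative activity, read by MTT assay, with a stated time of 3 days; a lower number here means a stronger inhibitor, a higher number a weaker inhibitor:
- compound 1 `CCCCCCCCC#Cc1cn(C/C=C\CN2C(=O)c3ccccc3C2=O)c(=O)[nH]c1=O` gives 39000 nM
- compound 2 `O=C1c2ccccc2C(=O)N1C/C=C\Cn1cc(C#Cc2ccc(Br)cc2)c(=O)[nH]c1=O` gives 89000 nM
- compound 3 `CCCCCCCCC#Cc1cn(C/C=C/CN2C(=O)c3ccccc3C2=O)c(=O)[nH]c1=O` gives 43000 nM

In this assay compound 3 gives 43000 nM, the second highest of the three numbers. It is level with compound 1, and compound 2 has the higher number.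

The next compound is compound 4 `O=C1c2ccccc2C(=O)N1C/C=C/Cn1cc(C#CCCc2ccccc2)c(=O)[nH]c1=O`. The change is phenyl in place of hexyl on a saturated chain carbon, two bonds along the chain from a triple-bonded carbon.

Among the measured compounds shown here, two measured steps bear on this. The double-bond configuration alone gives a 1.1-fold higher number from compound 1 to compound 3 (0.04 log units; within the scatter), so compounds 1 and 3 serve equally as references. For the measured compounds named here, the closest precedent for a ring replacing the chain, 4-bromophenyl in place of octyl on a triple-bonded carbon, gives a 2.3-fold higher number from compound 1 to compound 2 (0.36 log units; beyond the scatter), a modest step.

On that single case, a small move toward a higher number is expected, with an estimated 1.3-fold higher number from compound 3 to compound 4 (0.11 log units; within the scatter). The expected value for compound 4 is 55000 nM, with an estimated range of 25000 nM to 120000 nM.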

Compound 4, half-maximal inhibitory concentration: 7300 nM
Compound 4: middle estimate off by 7.5-fold (0.88 log units), on the high side; measured number outside the range, below it.
By their numbers in this assay, from the lowest: compound 4; then compounds 1 and 3 (each within the scatter of the next); then compound 2.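

In this assay, a 5.9-fold lower number from compound 3 to compound 4 (0.77 log units; beyond the scatter) is the only step shown that lowers the number beyond the scatter, and it comes with no change in heavy-atom count between hexyl and phenyl. A ring in place of a chain therefore has no single direction in this series: with 4-bromophenyl on a triple-bonded carbon the result is a 2.3-fold higher number from compound 1 to compound 2 (0.36 log units; beyond the scatter), although that ring also carries bromine and sits at a different place. Nothing at hand gives a cause for the lower number in compound 4.

Open, from the compounds shown here alone, is how far the phenyl can move along the chain, as with benzyl or a longer chain ending in phenyl, and whether an amine or a carboxylic acid on that ring is tolerated. Also open, going by these compounds, is whether the double-bond configuration stays without effect when the side chain ends in phenyl.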